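A Pyridine Variant of a Biphenyl Cyanoazetidine

The source may hold more compounds than are shown below. What is called first, only, known or untested is meant among the compounds shown, and "the series" means these compounds.

Compound 1 `N#CN1CC(OCc2ccc(-c3ccccc3)cc2)C1` gives 2.8 nM in an assay on isolated protein for inhibition of N-acylethanolamine-hydrolyzing acid amidase (Homo sapiens), read by fluorescence, with a stated time of 90 min (a lower number here means a stronger inhibitor, a higher number a weaker inhibitor), the lowest of the three numbers recorded here. Compound 2 `N#CN1CC(Oc2ccc(-c3ccccc3)cc2)C1` gives 29 nM in this assay, a higher number lying beyond the usual scatter, and compound 3 `COc1cccc(OC)c1-c1ccc(COC2CN(C#N)C2)cc1` gives 67.5 nM, higher still and also beyond the scatter. Compound 4 `N#CN1CC(OCc2ccc(-c3cccnc3)cc2)C1` has not been measured; it differs from compound 1 by pyridin-3-yl in place of phenyl on an aromatic carbon. Going by the values given here, no measured pair shows this particular change, so the size of the step cannot be read from the recorded compounds, and only a small change, at most slightly beyond the scatter, is expected. The step from compound 1 to compound 4 is expected to be a 1.8-fold higher number from compound 1 to compound 4 (0.25 log units; within the scatter). Compound 4 is therefore estimated at 5 nM, with a likely range from 1.5 nM to 20 nM.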

Compound 4, half-maximal inhibitory concentration: 12 nM
Beside the measured number, compound 4's estimate is 2.4-fold (0.38 log units) below it; measured number inside the range.
By their numbers in this assay, from the lowest: compound 1; then compound 4; then compound 2; then compound 3.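

Placing pyridin-3-yl in place of phenyl, on an aromatic carbon para to a group of 8 heavy atoms, gives a 4.3-fold higher number from compound 1 to compound 4 (0.63 log units; beyond the scatter) in this assay. Going by these compounds alone, this is the first single-change step at this position, and it shows that this one swap, with the same heavy-atom count, moves the number beyond the scatter, though only modestly. Nothing at hand accounts for the direction of this step.

On these data alone, whether pyridin-2-yl or pyridin-4-yl would give a step of similar size remains open. So does the effect of an amine or a carboxylic acid on this terminal ring.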